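A benzyl swap with little to lean on

The source may report more compounds than this note shows. Statements on the series, on what has been measured and on what is new or still open speak of the compounds shown alone.

In a functional assay on B16 cells (Mus musculus) for antiproliferative activity, with a stated time of 72 h (a higher number here means a weaker inhibitor, a lower number a stronger inhibitor), the series offers few firm numbers. Compound 1 `OC[C@H]1O[C@@H](n2cnc3c(NCc4ccccc4Cl)ncnc32)[C@H](O)[C@@H]1O` gives > 166000 nM, which is a limit of the assay and not a number. Compound 2 `OC[C@H]1O[C@@H](n2cnc3c(NCc4ccc(Cl)c(Cl)c4)ncnc32)[C@H](O)[C@@H]1O` gives > 166000 nM, which is also a limit. The exchange of 2-chlorophenyl for 3,4-dichlorophenyl is therefore a step that the two limits leave unreadable from compound 1 to compound 2. For compound 3 `OC[C@H]1O[C@@H](n2cnc3c(NCc4cccc(O)c4O)ncnc32)[C@H](O)[C@@H]1O`, the entry reads "not determined" (no result reported), so it has no single number and no place of its own on the scale. The only reference nearby is the limit of > 166000 nM in this assay, at which 2 of the 3 values shown sit.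

Compound 4 `Cc1ccc(O)c(CNc2ncnc3c2ncn3[C@@H]2O[C@H](CO)[C@@H](O)[C@H]2O)c1` carries 2-hydroxy-5-methylphenyl in place of the 2,3-dihydroxyphenyl of compound 3, on a saturated chain carbon bound to a nitrogen on an aromatic ring: 2-hydroxy-5-methylphenyl in place of 2,3-dihydroxyphenyl on a saturated chain carbon bound to a nitrogen on an aromatic ring. Going by the values given here, the one measured step concerns chlorinated groups and has no readable size, and compound 3 offers no starting value. No size or direction can therefore be expected for this change. The expectation rests only on (the limit of > 166000 nM in this assay, at which 2 of the 3 values shown sit), and a result at that limit seems the likeliest outcome, although a measurable value cannot be excluded. Compound 4 is estimated at 100000 nM, with an expected range from 15000 nM to 166000 nM.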

Compound 4, half-maximal inhibitory concentration: > 166000 nM
Compound 4 was reported as a limit; the forecaster's own chance of this, stated with the estimate: 60%; middle value at least 1.6-fold (0.22 log units) away from the limit.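

In this assay compound 4 gives > 166000 nM, which is a limit of the assay and not a number. Going by these compounds alone, its steps from compound 1 and from compound 2 join two limits, so they cannot be read and no new step emerges. The compounds shown leave open whether any of these phenyl groups on the shared core gives a measurable value in this assay.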